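Amide substituent series: the step to compound 4

The compounds below may be only part of what the source reports. "The series", "measured", "known", "first", "only" and "open" are said of these compounds alone.

Among the compounds with values here, in a functional assay on the whole organism for inhibition, with Rattus norvegicus as the target, read by paw edema, at a dose of 100 mg/kg by the oral route (on this read-out lower numbers stand for less inhibition and higher numbers for more inhibition at the one dose given (going by the name of the read-out)), compound 1 `CN(C)CCNC(=O)c1c(O)c2cccnc2n(-c2ccccc2)c1=O` gives 22.6%, the second highest of the three numbers so far. Compound 2 `Cc1ccccc1NC(=O)c1c(O)c2cccnc2n(-c2ccccc2)c1=O` gives 11.7% in this assay; compound 3 `O=C(Nc1ccncc1)c1c(O)c2cccnc2n(-c2ccccc2)c1=O` gives 34.9% in this assay. The steps are a number 10.9 percentage points lower from compound 1 to compound 2 (beyond the scatter) and a number 12.3 percentage points higher from compound 1 to compound 3 (beyond the scatter), with a number 23.2 percentage points higher from compound 2 to compound 3 (beyond the scatter) between the two measured neighbours. Compound 4 `O=C(NCc1ccncc1)c1c(O)c2cccnc2n(-c2ccccc2)c1=O` differs from compound 1 by pyridin-4-yl in place of (dimethylamino)methyl on a saturated chain carbon bound to an amide-type nitrogen. Within the data shown here, the closest measured step is the one to compound 3, where the same pyridin-4-yl sits directly on the amide-type nitrogen; here it sits one saturated chain carbon further out, so a smaller rise than a number 12.3 percentage points higher from compound 1 to compound 3 (beyond the scatter) is expected. Compound 4 is estimated at 30% in this assay, between 15% and 45%, a step of a number 7.4 percentage points higher from compound 1 to compound 4 (within the scatter).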

Compound 4, a percentage reported as inhibition, in the whole organism at one dose (the size of the read-out at that dose, not a potency): 10%
For compound 4 the middle estimate is 20 percentage points above the measured one, and the stated range ends above it.
By their numbers in this assay, from the lowest: compounds 4 and 2 (each within the scatter of the next); then compound 1; then compound 3.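

In this assay, one saturated chain carbon inserted between the amide-type nitrogen and the pyridin-4-yl removes most of the response seen with the directly attached ring (a number 24.9 percentage points lower from compound 3 to compound 4 (beyond the scatter)). The pyridin-4-yl ring alone therefore does not carry the response at this position: (pyridin-4-yl)methyl also falls short of 2-(dimethylamino)ethyl (a number 12.6 percentage points lower from compound 1 to compound 4 (beyond the scatter)) and is not separated from 2-methylphenyl (a number 1.7 percentage points lower from compound 2 to compound 4 (within the scatter)). Nothing available accounts for this loss. Still open, from the compounds shown here alone, is how a longer chain, such as 2-(pyridin-4-yl)ethyl, would read, and whether an unsubstituted phenyl on the amide-type nitrogen would match the directly attached pyridin-4-yl.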